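Notes on a sulfonamide series: the amine substituent

This account rests on a few compounds, and the source may have more. Where it says the series, first, only, none or still open, it means among the compounds named here.

Measured compounds: compound 1 `O=C(c1ccc(C(F)(F)F)cc1)N1CCC(NS(=O)(=O)c2cc(S(=O)(=O)c3ccccc3)ccc2C(F)(F)F)CC1`, 970 nM; compound 2 `O=C(O)c1ccc(S(=O)(=O)N2CCC(NS(=O)(=O)c3cc(S(=O)(=O)c4ccccc4)ccc3C(F)(F)F)CC2)cc1`, 110 nM; compound 3 `O=C(O)c1ccc(N2CCC(NS(=O)(=O)c3cc(S(=O)(=O)c4ccccc4)ccc3C(F)(F)F)CC2)cc1`, 230 nM, all in an assay on U2OS cells for inhibition of secreted frizzled-related protein 1 (Homo sapiens), read by a luciferase reporter, with a stated time of 18 h; a higher number here means that more compound is needed for the effect, a lower number that less compound is needed.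

Compound 1 gives the highest number of the three; its nearest neighbour is compound 3, at a 4.2-fold lower number from compound 1 to compound 3 (0.63 log units; beyond the scatter), and the furthest is compound 2, at an 8.8-fold lower number from compound 1 to compound 2 (0.95 log units; beyond the scatter). Compound 4 `CC(C)(C)OC(=O)N1CC[C@H](C(=O)N2CCC(NS(=O)(=O)c3cc(S(=O)(=O)c4ccccc4)ccc3C(F)(F)F)CC2)C1` is not yet measured. It differs from compound 1 by 1-(tert-butoxycarbonyl)pyrrolidin-3-yl in place of 4-(trifluoromethyl)phenyl on a carbonyl carbon. The measured steps all exchange the whole group on the amine nitrogen in the ring, so none of them matches this change, which keeps the carbonyl; they show only that this position can move the number by a modest amount. No direction can be read from them, so a step close to none, or a modest drop, is expected, a 1.2-fold lower number from compound 1 to compound 4 (0.08 log units; within the scatter). Compound 4 is therefore estimated at 800 nM, with a range from 250 nM to 2500 nM.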

Compound 4, half-maximal effective concentration: 150 nM
For compound 4 the middle estimate is 5.3-fold (0.73 log units) above the measured one; the whole stated range lies above it.
By their numbers in this assay, from the lowest: compounds 2, 4 and 3 (each within the scatter of the next, the first and the last beyond it); then compound 1.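

In this assay, the number moves with the carbonyl kept and only the group on it exchanged, a 6.5-fold lower number from compound 1 to compound 4 (0.81 log units; beyond the scatter), so this position responds without replacing the whole group on the ring nitrogen. The 4-(trifluoromethyl)phenyl group is not required on this carbonyl carbon, and a non-aromatic 1-(tert-butoxycarbonyl)pyrrolidin-3-yl group is tolerated there. No supporting measurement accounts for the step.

As far as these compounds go, it remains open which part of the entering group carries the step; a free amine or an acetyl group on the pyrrolidine nitrogen would separate the ring from the tert-butoxycarbonyl group. From the compounds shown here alone, the effect of the opposite configuration at the stereocentre also remains open.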